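Swapping Trifluoromethyl for Iodo: From Compound 3 to Compound 4

The compounds below may be only part of what the source reports. "The series", "measured", "known", "first", "only" and "open" are said of these compounds alone.

Of the compounds shown here, three have so far been measured in an ADME assay on the whole organism with Oryza sativa as the target, tested at 10 uM; on this read-out higher numbers stand for a weaker effect at the one concentration tested and lower numbers for a stronger effect. Compound 1 `CCCCc1ccc(NC(=O)N[C@@H](C)c2ccccc2)cc1` gives 60%. Compound 2 `C[C@@H](NC(=O)Nc1ccccc1C(F)(F)F)c1ccccc1` gives 54%, and compound 3 `C[C@H](NC(=O)Nc1ccccc1C(F)(F)F)c1ccccc1` gives 97%. Compound 3 thus stands highest of the three numbers, beyond the scatter against both others. Among the measured compounds shown here, the only step between two closely related measured compounds is a number 43 percentage points higher from compound 2 to compound 3 (beyond the scatter), and this large step rests solely on the fact that compounds 2 and 3 differ only in the configuration as drawn: the two share every atom and bond and differ only in how one centre is drawn. Compound 4 `C[C@H](NC(=O)Nc1ccccc1I)c1ccccc1` departs from compound 3 by iodo in place of trifluoromethyl on an aromatic carbon. For the measured compounds named here, no measured step touches a change of this kind: the one step known concerns configuration rather than the group on the ring, so it offers no guide to direction or size here. The expectation is therefore a step of a number 12 percentage points lower from compound 3 to compound 4 (beyond the scatter), close to none beyond the scatter but with a wide range. Compound 4 is estimated at 85%, between 55% and 100%.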

Compound 4, a percentage reported as activity, at one concentration (the size of the read-out at that concentration, not a potency): 98%
Beside the measured number, compound 4's estimate is 13 percentage points below it; the range from low to high includes it.
By their numbers in this assay, from the lowest: compounds 2 and 1 (each within the scatter of the next); then compounds 3 and 4 (each within the scatter of the next).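

Exchanging trifluoromethyl, with its 4 heavy atoms, for iodo, with 1 heavy atom, on this aromatic carbon ortho to a large group gives a number 1 percentage points higher from compound 3 to compound 4 (within the scatter) in this assay. Among the compounds shown here, the read-out thus does not separate these two groups in the configuration shared by compound 3 and compound 4, whereas the earlier compounds showed only what a change of configuration does, not what a change of group on the ring does. Nothing at hand explains why the two groups read alike.

Going by these compounds, it remains open whether the same exchange would also read alike in the configuration of compound 2. On these data alone, it is equally open whether a group of another kind on this carbon, such as an amine or a carboxylic acid, would move the number at all.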